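The compounds below may be only part of what the source reports. "The series", "measured", "known", "first", "only" and "open" are said of these compounds alone.

Compound 1, `Nc1nc(N)c2c(-c3ccsc3)cn([C@@H]3O[C@H](CO)[C@@H](O)[C@H]3O)c2n1`, is tested in a functional assay on HCT-116 cells (Homo sapiens), read by MTT assay, with a stated time of 72 h; a lower number here means a stronger inhibitor, a higher number a weaker inhibitor. In this assay compound 1 gives > 20000 nM, which is a limit of the assay rather than a number. Compound 2, `COc1ncnc2c1c(-c1ccsc1)cn2[C@@H]1O[C@H](CO)[C@@H](O)[C@H]1O`, gives 120 nM in this assay. Compound 3, `Cc1nc(N)c2c(-c3ccco3)cn([C@@H]3O[C@H](CO)[C@@H](O)[C@H]3O)c2n1`, gives > 20000 nM in this assay, again a limit and not a number. Going by the values given here, compound 1 therefore stands at the limit of > 20000 nM in this assay, at which 2 of the 3 values shown sit, and no step between two measured compounds that differ in one place is available, so the size of any step can only be guessed. Compound 4, `Nc1nc(N)c2c(-c3ccccc3)cn([C@@H]3O[C@H](CO)[C@@H](O)[C@H]3O)c2n1`, has not yet been measured in this assay. The change from compound 1 to compound 4 is phenyl in place of thiophen-3-yl on an aromatic carbon. Because compound 1 sits at the limit of > 20000 nM in this assay, at which 2 of the 3 values shown sit, the step to compound 4 can only be judged from that limit. Compound 4 is expected to remain near the limit, so the estimated step is a number no higher from compound 1 to compound 4 (the limit leaves the size open), none beyond the scatter. Compound 4 is estimated at 20000 nM, with a range from 4000 nM to 100000 nM.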

Compound 4, half-maximal inhibitory concentration: > 20000 nM
Compound 4: a limit, no number; the forecaster's own chance of this, stated with the estimate: 75%; the middle value lies on the limit itself.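

No step can be read from compound 1 to compound 4, because each gives only a limit of the assay and not a number: the limit of > 20000 nM in this assay, at which 3 of the 4 values shown sit. The compounds shown leave open whether phenyl in place of thiophen-3-yl on the shared core changes the inhibition at all.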